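This account rests on a few compounds, and the source may have more. Where it says the series, first, only, none or still open, it means among the compounds named here.

Compound 2 `CNC(=O)c1cc(Oc2ccc3nc(NC(=O)c4ccc(Cl)cc4Cl)sc3c2)ccn1` stands lowest of the two numbers measured in a functional assay on HCT-116 cells (Homo sapiens) for inhibition, read by MTT assay, with a stated time of 2 days, tested at 100 uM (a higher number here means more inhibition of growth at the concentration tested, a lower number less inhibition of growth), where compound 2 gives 64.4%; compound 1 `CNC(=O)c1cc(Oc2ccc3nc(NC(=O)Nc4cc(C(F)(F)F)cc(C(F)(F)F)c4)sc3c2)ccn1` gives 98.4%, a number higher by more than the usual scatter. Compound 3 `CNC(=O)c1cc(Oc2ccc3nc(NC(=O)c4ccc(Cl)cc4)sc3c2)ccn1` differs from compound 2 by hydrogen in place of chloro on an aromatic carbon. For the measured compounds named here, no measured pair shows this change, so the size of the step is open; a modest move in either direction, or none beyond the scatter, is expected. Compound 3 is estimated at 55% in this assay, within 30% to 80%. The expected step is a number 9.4 percentage points lower from compound 2 to compound 3 (within the scatter).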

Compound 3, percent growth inhibition at one concentration: 80.5%
Compound 3: middle estimate off by 25.5 percentage points, on the low side, and the stated range ends below it.
By their numbers in this assay, from the lowest: compound 2; then compound 3; then compound 1.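

In this assay, for the compounds shown here, the change from 2,4-dichlorophenyl to 4-chlorophenyl gives a number 16.1 percentage points higher from compound 2 to compound 3 (beyond the scatter) and so puts the first measured step on this position. On this carbon, ortho to a large group, the chloro is not needed for growth inhibition at the concentration tested, and hydrogen does better there. Nothing measured here explains the step.

The compounds shown hold only chloro or hydrogen on this carbon, so a methoxy group or an amine there remains open. So does the effect of the remaining chloro on the ring.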